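Two cores, two dichlorophenyl patterns: notes toward compound 4

The source may report more compounds than this note shows. Statements on the series, on what has been measured and on what is new or still open speak of the compounds shown alone.

Compound 1 `COc1cccc(/C=C2\CCC/C(=C\c3ccc(Cl)cc3Cl)C2=O)c1OC` carries a 2,4-dichlorophenyl group; in a functional assay on SW-620 cells (Homo sapiens) for cytotoxicity, read by MTT assay, with a stated time of 72 h (a higher number here means a weaker inhibitor, a lower number a stronger inhibitor), compound 1 gives 16300 nM. Compound 2 `COc1cccc(/C=C2\CCC/C(=C\c3ccc(Cl)c(Cl)c3)C2=O)c1OC` differs from it by 3,4-dichlorophenyl in place of 2,4-dichlorophenyl on a double-bonded chain carbon bound to a double-bonded ring carbon, and in this assay compound 2 gives 10000 nM. Going by the values given here, the step of a 1.6-fold lower number from compound 1 to compound 2 (0.21 log units; within the scatter) is the only measured instance of this change in the set.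

Compound 3 `COc1ccc(/C=C2\CCC/C(=C\c3ccc(Cl)cc3Cl)C2=O)cc1OC` keeps the 2,4-dichlorophenyl group of compound 1 on a different core; the difference between the two cores is not broken down here. In this assay compound 3 gives 10300 nM. The values of compound 2 and compound 3 lie within the scatter of each other, as do those of compound 1 and compound 3, so no ranking among the three measured compounds can be drawn from these numbers.

Compound 4 `COc1ccc(/C=C2\CCC/C(=C\c3ccc(Cl)c(Cl)c3)C2=O)cc1OC` is the partner of compound 3 on the second core, differing from it by 3,4-dichlorophenyl in place of 2,4-dichlorophenyl on a double-bonded chain carbon bound to a double-bonded ring carbon, the same change as that from compound 1 to compound 2, at the same place. The change occurs twice among the compounds shown, once measured. Because the measured step of a 1.6-fold lower number from compound 1 to compound 2 (0.21 log units; within the scatter) was small, the step for compound 4 is expected to be of like size, namely a 1.5-fold lower number from compound 3 to compound 4 (0.17 log units; within the scatter). A single measured instance on a different core is thin support, so the range is kept wide. Compound 4 is therefore expected to give 7000 nM in this assay, with the estimate spanning 3000 nM to 16000 nM.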

Compound 4, half-maximal inhibitory concentration: 4000 nM
Estimate against measurement, compound 4: 1.8-fold (0.24 log units) above, within the range that was stated.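

In this assay, 3,4-dichlorophenyl in place of 2,4-dichlorophenyl on the second core gives a 2.6-fold lower number from compound 3 to compound 4 (0.41 log units; beyond the scatter), a modest step but one that stands clear of the scatter. Set beside the earlier instance of the change on the first core, this step does not differ from it by more than the scatter of two such steps allows: the same change on two cores in this assay, a 1.6-fold lower number (0.21 log units; within the scatter) from compound 1 to compound 2 and a 2.6-fold lower number (0.41 log units; beyond the scatter) from compound 3 to compound 4, 1.6-fold (0.20 log units) apart, within the scatter of two such steps

So the change carries from one core to the other with no detectable difference in step size, and the step points the same way on both cores. It does not show that the change has a firm effect on every core, since the step on the first core lies within the scatter, nor that the second core responds more strongly, and two pairs say nothing about any further core.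

The compounds shown leave open whether the gain in this assay belongs to the 3,4-dichlorophenyl pattern as such or would also appear with a single chlorine, a nitrile or a trifluoromethyl group at that place. They also leave open how an amine or a carboxylic acid on that ring would behave on either core, and what the two cores contribute on their own.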